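Trading the Ester Chain for a Methoxy Group

The source may hold more compounds than are shown below. What is called first, only, known or untested is meant among the compounds shown, and "the series" means these compounds.

Of the compounds shown here, three built on one shared core have been measured. Compound 1 `CCC1CCc2c(sc(NC(=O)Nc3ccc(Cl)cc3)c2C(N)=O)C1` carries no amine in its ring, and in a functional assay (strain AB) with Danio rerio as the target, read by microscopy, with a stated time of 1 h (a lower number here means that less compound is needed, a higher number that more compound is needed for the effect), compound 1 reaches only the assay limit, > 25000 nM. Compound 3 `CCN1CCc2c(sc(NC(=O)Nc3cccc(C)c3)c2C(N)=O)C1` bears a small ethyl group on the amine nitrogen in a ring and gives 13000 nM. Compound 2 `CC(C)(C)OC(=O)CCCC[N+]1(C)CCc2c(sc(NC(=O)Nc3ccc(Cl)cc3)c2C(N)=O)C1`, with a longer chain on that nitrogen, gives 140 nM, the lowest of the two real numbers, and its gap to compound 3 lies well beyond the usual scatter. Compound 4 `COCCC[N+]1(C)CCc2c(sc(NC(=O)Nc3ccc(Cl)cc3)c2C(N)=O)C1` keeps the same ring nitrogen but trims the chain: methoxy in place of (tert-butoxycarbonyl)methyl on a saturated chain carbon, three bonds along the chain from an amine nitrogen in a ring. A modest weakening, somewhat beyond the scatter, is expected, a 2.9-fold higher number from compound 2 to compound 4 (0.46 log units; beyond the scatter). Compound 4 is expected to give 400 nM, within 100 nM to 2000 nM.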

Compound 4, half-maximal effective concentration: 480 nM
Beside the measured number, compound 4's estimate is 1.2-fold (0.08 log units) below it, and the stated range covers the measured number.
By their numbers in this assay, from the lowest: compound 2; then compound 4; then compound 3. At a limit, above all of these: compound 1.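

In this assay, the long ester chain proves not to be essential at this position: replacing 4-(tert-butoxycarbonyl)butyl with 3-methoxypropyl costs only a modest step, a 3.4-fold higher number from compound 2 to compound 4 (0.54 log units; beyond the scatter), even though the carbonyl is lost. Among these compounds, this is the only step in the set that changes a single place, so it is the first direct reading of what this chain contributes.

Open, going by these compounds, is how a carboxylic acid or an amine at the chain end, or a longer methoxy-bearing chain, would compare at this position. Nothing measured here accounts for the size of this step.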